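A few compounds are considered here, and "the series" means these few. Any claim that something is new, unique, unknown or untested is made for them only; others in the source may bear on it.

Measured so far in a functional assay on RAW264.7 cells (Mus musculus) for inhibition, read by Griess assay, with stated times of 1 h and 24 h; on this read-out lower numbers stand for stronger inhibition and higher numbers for weaker inhibition:

Compound 1, `O=C1OC(Cc2nc(-c3ccc(Oc4ccccc4)cc3)no2)c2ccccc21`, gives > 10000 nM, which is a limit of the assay and not a number.
Compound 2, `CCOc1ccc(C(O)C2OC(=O)c3c(OC)cc(OC)cc32)cc1`, gives > 10000 nM, again only a limit.
Compound 3, `COCCOc1ccc(C(O)C2OC(=O)c3c(OC)cc(OC)cc32)cc1`, gives > 10000 nM, also a limit.

For the measured compounds named here, compound 2 therefore has no resolved position in this assay; all three values sit at the same limit, as the limit of > 10000 nM in this assay, at which 3 of the 3 values shown sit, shows, so no compound can be ranked against another.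

Going by the values given here, the only measured step that touches the same part of the structure is a step that the two limits leave unreadable from compound 2 to compound 3, the exchange of hydrogen for methoxy on a saturated chain carbon two bonds along the chain from an oxygen on an aromatic ring. Both ends of that step are limits, so its size cannot be read.

Compound 4, `COc1cc(OC)c2c(c1)C(C(O)c1ccc(OCc3ccc(F)cc3)cc1)OC2=O`, differs from compound 2 as follows: 4-fluorophenyl in place of methyl on a saturated chain carbon bound to an oxygen on an aromatic ring. This extends the same chain carbon bound to an oxygen on an aromatic ring, but with a ring in place of a methyl, a change of a kind the measured steps do not cover. The measured evidence gives no readable step in either direction, so the expectation for compound 4 rests on the unresolved limit of compound 2 alone.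

For compound 4 the expected result in this assay is 10000 nM, in the range 3000 nM to 30000 nM, most likely reported again as a limit. The expected step is a number no higher from compound 2 to compound 4 (the limit leaves the size open), with no direction that can be supported by the measured values.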

Compound 4, half-maximal inhibitory concentration: 760 nM
The estimate for compound 4 lay 13-fold (1.12 log units) above the measured number; measured number outside the range, below it.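

In this assay, 4-fluorophenyl in place of methyl on a saturated chain carbon bound to an oxygen on an aromatic ring gives an at least 13-fold lower number from compound 2 to compound 4 (1.11 log units; beyond the scatter), and 4-fluorophenyl in place of methoxymethyl on that carbon gives an at least 13-fold lower number from compound 3 to compound 4 (1.11 log units; beyond the scatter). The group on this chain carbon can therefore move the read-out well beyond the scatter, which compound 2 and compound 3 could not show, as the step between them cannot be read with both ends at a limit. Compound 4 is the only compound shown with a resolved number, so the series has just one fixed point on the scale, and the other three values stay at the limit: the limit of > 10000 nM in this assay, at which 3 of the 4 values shown sit.

On these data alone, it remains open whether the lower number follows from the aromatic ring or from the fluorine, a question that a plain benzyl group with hydrogen in place of fluorine, or a 4-chlorobenzyl group, would address. Also open, as far as these compounds go, is how far the position tolerates other groups, such as a longer chain ending in phenyl, or a benzyl group carrying an amine or a carboxylic acid on its ring.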